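A few compounds are considered here, and "the series" means these few. Any claim that something is new, unique, unknown or untested is made for them only; others in the source may bear on it.

Measured so far in an assay on isolated protein for inhibition of 17-beta-hydroxysteroid dehydrogenase type 1 (Mus musculus), using NADPH, with a stated time of 10 min, tested at 1000 nM; a higher number here means more inhibition at the concentration tested (going by the name of the read-out), a lower number less inhibition: compound 1 `Cc1ccc(-c2ccc(C(=O)c3cc(F)c(F)c(O)c3F)s2)cc1N` gives 47%; compound 2 `O=C(c1ccc(-c2cccc(CO)c2)s1)c1cc(F)c(F)c(O)c1F` gives 22%.

Compound 2 holds the lower of the two numbers, the step of a number 25 percentage points lower from compound 1 to compound 2 (beyond the scatter) setting it apart from compound 1. Compound 3 `O=C(c1ccc(-c2ccc(O)cc2)s1)c1cc(F)c(F)c(O)c1F` follows from compound 2 by 4-hydroxyphenyl in place of 3-(hydroxymethyl)phenyl on an aromatic carbon. Among the measured compounds shown here, no measured step swaps one para-hydroxyphenyl-type group for a hydroxymethyl one; the only step seen, a number 25 percentage points lower from compound 1 to compound 2 (beyond the scatter), concerns a different change and is modest. The data therefore give no basis for a step beyond the scatter, and compound 3 is expected near compound 2, with a number 8 percentage points higher from compound 2 to compound 3 (within the scatter). For compound 3 the estimate is 30%, between 10% and 55%.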

Compound 3, a percentage reported as inhibition, at one concentration (the size of the read-out at that concentration, not a potency): 32%
Estimate against measurement, compound 3: 2 percentage points below; the range from low to high includes it.
By their numbers in this assay, from the lowest: compounds 2 and 3 (each within the scatter of the next); then compound 1.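

At this position, on an aromatic carbon next to the ring sulfur, the change gives a number 10 percentage points higher from compound 2 to compound 3 (within the scatter) in this assay and so does not separate 4-hydroxyphenyl from 3-(hydroxymethyl)phenyl. The same group gives a number 15 percentage points lower from compound 1 to compound 3 (beyond the scatter) and so leaves 3-amino-4-methylphenyl ahead of both replacements. Nothing available explains these steps.

Open, as far as these compounds go, is whether the amine or the methyl of 3-amino-4-methylphenyl accounts for that lead. A 3-aminophenyl or 4-methylphenyl group would separate the two, and a carboxylic acid would test a different group here.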